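Replacing the 2,5-dimethoxyphenyl group of compound 3

The compounds below may be only part of what the source reports. "The series", "measured", "known", "first", "only" and "open" are said of these compounds alone.

In a functional assay on U-87MG ATCC cells (Homo sapiens) for cytotoxicity, read by MTT assay, with a stated time of 72 h (on this read-out higher numbers stand for weaker inhibition and lower numbers for stronger inhibition), compound 3 (`COc1ccc(OC)c(/C=N/NC(=O)Nc2ccc(Oc3ccnc(-c4nncn4CCN(C)C)c3)c(F)c2)c1`) gives 6400 nM as the higher of the two true numbers. Compound 2 (`CN(C)CCn1cnnc1-c1cc(Oc2ccc(NC(=O)N/N=C/c3c[nH]c4ccccc34)cc2F)ccn1`) lies lower with 690 nM as its value. Compound 1 (`CN(C)CCn1cnnc1-c1cc(Oc2ccc(NC(=O)N/N=C/c3c(Cl)cccc3Cl)cc2F)ccn1`) shows > 100000 nM as a limit of the assay and not a number. Compound 4 (`CN(C)CCn1cnnc1-c1cc(Oc2ccc(NC(=O)N/N=C/c3ccc(O)c(Br)c3)cc2F)ccn1`) has 3-bromo-4-hydroxyphenyl in place of 2,5-dimethoxyphenyl on a carbon with a double bond to nitrogen. Three measured steps at this same place bear on it: an at least 140-fold lower number from compound 1 to compound 2 (2.16 log units; beyond the scatter) (large), an at least 15-fold lower number from compound 1 to compound 3 (1.19 log units; beyond the scatter) (large) and a 9.3-fold higher number from compound 2 to compound 3 (0.97 log units; beyond the scatter) (modest). Changes here have moved the number beyond the scatter, so a modest step towards a lower number is expected in this assay with its direction uncertain. The expected step is a 1.6-fold lower number from compound 3 to compound 4 (0.20 log units; within the scatter) (an estimate). Compound 4 is estimated at 4000 nM (expected range 700 nM to 30000 nM).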

Compound 4, half-maximal inhibitory concentration: 12400 nM
Estimate against measurement, compound 4: 3.1-fold (0.49 log units) below; low and high end bracket the measured number.
By their numbers in this assay, from the lowest: compound 2; then compounds 3 and 4 (each within the scatter of the next). At a limit, above all of these: compound 1.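

In this assay, 3-bromo-4-hydroxyphenyl and 2,5-dimethoxyphenyl prove interchangeable within the scatter, with a 1.9-fold higher number from compound 3 to compound 4 (0.29 log units; within the scatter), although the two groups share no substituent. The 1H-indol-3-yl group keeps its distance from this new group too, with an 18-fold higher number from compound 2 to compound 4 (1.25 log units; beyond the scatter), while the 2,6-dichlorophenyl comparison gives an at least 8.0-fold lower number from compound 1 to compound 4 (0.90 log units; beyond the scatter). That last step rests on a limit and not a number: the limit of > 100000 nM in this assay, at which 1 of the 4 values shown sits.

The compounds shown leave open whether the bromine or the hydroxy group matters more in 3-bromo-4-hydroxyphenyl. They also leave open whether another nitrogen ring, such as an imidazole or a 1H-pyrrol-2-yl group, would match 1H-indol-3-yl.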